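Shortening the linker to the hydroxycarbamoyl group

The source may report more compounds than this note shows. Statements on the series, on what has been measured and on what is new or still open speak of the compounds shown alone.

Compound 1 `Nc1ncnc2c1c(-c1cnc3[nH]ccc3c1)nn2CCCCCCCCC(=O)NO`: in a functional assay on CNE-2 cells (Homo sapiens) for inhibition, read by MTT assay, with a stated time of 72 h (on this read-out lower numbers stand for stronger inhibition and higher numbers for weaker inhibition), compound 1 gives 2270 nM.
Compound 2 `Nc1ncnc2c1c(-c1cnc3[nH]ccc3c1)nn2CCCCC(=O)NO`: for compound 2 this assay records only a limit, > 150000 nM.
Compound 3 `Nc1nc2cc(-c3nn(CCCCCC(=O)NO)c4ncnc(N)c34)ccc2o1`: in this assay compound 3 gives 37600 nM.

Compounds 1 and 2 share one core and differ in a single place: hydroxycarbamoyl in place of 4-(hydroxycarbamoyl)butyl on a saturated chain carbon, four bonds along the chain from an aromatic nitrogen. That change produced an at least 66-fold higher number from compound 1 to compound 2 (1.82 log units; beyond the scatter). The value of compound 2 is a limit of the assay, not a measured number (the limit of > 150000 nM in this assay, at which 1 of the 3 values shown sits).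

Compound 3 carries a different core; how the two cores differ is not broken down here. Compound 4 `Nc1nc2cc(-c3nn(CC(=O)NO)c4ncnc(N)c34)ccc2o1` has not yet been measured. It differs from compound 3 by hydroxycarbamoyl in place of 4-(hydroxycarbamoyl)butyl on a saturated chain carbon bound to an aromatic nitrogen. The place is not quite the same as before: in compound 1 the chain carbon sits four bonds along the chain from an aromatic nitrogen, while in compound 3 it is bound to an aromatic nitrogen, so this is the same kind of change rather than the same change.

Compound 3 already sits at the weaker end, with 37600 nM, and the earlier step of an at least 66-fold higher number from compound 1 to compound 2 (1.82 log units; beyond the scatter) was large. Compound 4 is therefore expected to give about 250000 nM, which is an expected step of a 6.6-fold higher number from compound 3 to compound 4 (0.82 log units; beyond the scatter). The expected range for compound 4 runs from 50000 nM to 1500000 nM, and it is expected that the assay may again report only a limit.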

Compound 4, half-maximal inhibitory concentration: 12200 nM
Estimate against measurement, compound 4: 20-fold (1.31 log units) above; measured number below the stated range.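

In this assay, replacing 4-(hydroxycarbamoyl)butyl with hydroxycarbamoyl on the core of compound 3 gave a 3.1-fold lower number from compound 3 to compound 4 (0.49 log units; beyond the scatter), so the shorter chain brought a modest gain in inhibition here rather than the large loss seen on the core of compound 1. Set side by side, the two steps run in opposite directions, and the gap between them is larger than repeated measurements would explain: the same change on two cores in this assay, an at least 66-fold higher number (1.82 log units; beyond the scatter) from compound 1 to compound 2 and a 3.1-fold lower number (0.49 log units; beyond the scatter) from compound 3 to compound 4, at least 200-fold (2.30 log units) apart, beyond the scatter of two such steps
This shows that the change does not carry over between these two cores with a fixed size or even a fixed direction, but with one pair per core, and with the change sitting at a different place on the chain in each pair, it does not show what produces the difference, and the earlier step gives only a minimum size, as the entry for compound 2 is a limit and not a measured number: the limit of > 150000 nM in this assay, at which 1 of the 4 values shown sits.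

Within the data shown here, still open is how inhibition would change on the core of compound 3 with a longer chain, such as the one carried by compound 1. Also open, going by these compounds, is whether a carboxylic acid in place of the hydroxycarbamoyl group would keep any inhibition on either core.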